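The compounds below may be only part of what the source reports. "The series", "measured", "known", "first", "only" and "open" are said of these compounds alone.

Compound 1 `S=C(Nc1ccccc1)N1N=C(c2ccc(Cl)cc2)CC1c1ccc2c(c1)OCCO2` gives 187000 nM in a functional assay on HT-29 cells (Homo sapiens) for antiproliferative activity, read by MTT assay, with a stated time of 48 h; on this read-out lower numbers stand for stronger inhibition of growth and higher numbers for weaker inhibition of growth. Compound 2 `S=C(Nc1ccccc1)N1N=C(c2ccc(Br)cc2)CC1c1ccc2c(c1)OCCO2` gives 2580 nM in this assay. Compound 3 `CSc1ccc(C2=NN(C(=S)Nc3ccccc3)C(c3ccc4c(c3)OCCO4)C2)cc1` reaches only a limit of the assay, > 200000 nM.

Of the two plain numbers, compound 1 stands highest. Its nearest neighbour sits a 72-fold lower number from compound 1 to compound 2 (1.86 log units; beyond the scatter) away, a change of bromo for chloro. Compound 4 `COc1ccccc1C1=NN(C(=S)Nc2ccccc2)C(c2ccc3c(c2)OCCO3)C1` differs from compound 1 by 2-methoxyphenyl in place of 4-chlorophenyl on a carbon with a double bond to nitrogen. Within the data shown here, two measured steps touch the same chloro: a 72-fold lower number from compound 1 to compound 2 (1.86 log units; beyond the scatter) and an at least 1.0-fold higher number from compound 1 to compound 3 (0.02 log units; that floor lies within the scatter), one far beyond the scatter and one within it. Neither brings in a methoxy, so the expected step is uncertain and no change beyond the scatter is assumed. Compound 4 is estimated at 150000 nM, within 25000 nM to 200000 nM. That expected step is a 1.2-fold lower number from compound 1 to compound 4 (0.10 log units; within the scatter).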

Compound 4, concentration for 50% growth inhibition: 30500 nM
Estimate against measurement, compound 4: 4.9-fold (0.69 log units) above; measured number inside the range.
By their numbers in this assay, from the lowest: compound 2; then compound 4; then compound 1. At a limit, above all of these: compound 3.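

The carbon with a double bond to nitrogen tolerates a group with no halogen, and 2-methoxyphenyl improves on 4-chlorophenyl: a 6.1-fold lower number from compound 1 to compound 4 (0.79 log units; beyond the scatter). It also beats 4-(methylsulfanyl)phenyl, the other halogen-free group shown: an at least 6.5-fold lower number from compound 3 to compound 4 (0.81 log units; beyond the scatter). However, 4-bromophenyl remains the best of these groups, with a 12-fold higher number from compound 2 to compound 4 (1.07 log units; beyond the scatter).

Compound 3 gives only a limit, so its step is a floor: the limit of > 200000 nM in this assay, at which 1 of the 4 values shown sits.

As far as these compounds go, whether the methoxy itself or its place on the ring matters stays open, since 2-methoxyphenyl differs from the others in both. A 4-methoxyphenyl or 2-bromophenyl group would separate the two.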